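A few compounds are considered here, and "the series" means these few. Any claim that something is new, unique, unknown or untested is made for them only; others in the source may bear on it.

Four compounds built on one shared core are compared here, all carrying the same three methoxy groups on one ring and differing only in the group on the far ring. Compound 1 `COc1cc(-c2ncnn2-c2ccccc2)cc(OC)c1OC` carries an unsubstituted phenyl. In a functional assay on HeLa cells (Homo sapiens) for antiproliferative activity, read by MTT assay, with a stated time of 72 h (a lower number here means a stronger inhibitor, a higher number a weaker inhibitor), compound 1 reaches only the assay's limit, > 10000 nM. Compound 3 `COc1cc(-c2ncnn2-c2ccc(N)cc2)cc(OC)c1OC` carries an amino group in place of a hydrogen on that ring. In this assay compound 3 likewise reaches only the limit, > 10000 nM. Among the compounds with values here, the one step that can be drawn between measured compounds, a step that the two limits leave unreadable from compound 1 to compound 3, cannot be sized, because both ends sit at the limit of > 10000 nM in this assay, at which 2 of the 3 values shown sit. Compound 2 `COc1cc(-n2ncnc2-c2ccc(C)cc2)cc(OC)c1OC` is the only one of the three that gives an actual number: in this assay compound 2 gives 250 nM.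

Compound 4 `COc1cc(-n2ncnc2-c2ccc(SC)cc2)cc(OC)c1OC` is the untested member. Its difference from compound 2 is methylsulfanyl in place of methyl on an aromatic carbon. Within the data shown here, no measured step here exchanges one such para group for another, and the single measured step is unreadable, so nothing in these data points to a shift in either direction beyond the usual scatter. The step of a 1.2-fold higher number from compound 2 to compound 4 (0.08 log units; within the scatter) is therefore expected to stay within that scatter. Compound 4 is estimated at 300 nM, with a range from 100 nM to 1000 nM.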

Compound 4, half-maximal inhibitory concentration: 150 nM
Estimate against measurement, compound 4: 2.0-fold (0.30 log units) above; measured number inside the range.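

Within the data shown here, the step of a 1.7-fold lower number from compound 2 to compound 4 (0.22 log units; within the scatter) is the first step in this assay that can be read, since the only earlier step had a limit at both ends. It shows that at this place, on an aromatic carbon para to a large group, 4-methylphenyl can be exchanged for 4-(methylsulfanyl)phenyl with no change beyond the usual scatter, so the two compounds cannot be put in order of strength, even though methylsulfanyl brings a sulfur atom and a hydrogen-bond acceptor that methyl lacks. Nothing measured here gives a reason for this result or bears directly on this exchange.

Methyl and methylsulfanyl are the only two groups at this place that can be compared on this core, so it remains open whether the number would hold with a different kind of group, such as an amine, a carboxylic acid or a longer chain like ethylsulfanyl. A plain hydrogen at this place on the same core also stands open, and it would show whether either group matters at all.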